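This account rests on a few compounds, and the source may have more. Where it says the series, first, only, none or still open, it means among the compounds named here.

Measured in a functional assay on PC-3 cells (Homo sapiens) for inhibition, read by colorimetric assay and MTT assay, with a stated time of 72 h; a higher number here means a weaker inhibitor, a lower number a stronger inhibitor:
- compound 1 `CCCCOc1ncc(-c2ccccc2OC)n1C`: 71000 nM
- compound 2 `CCCCCCOc1ncc(-c2ccccc2OC)n1C`: 33000 nM
- compound 3 `C=CCCOc1ncc(-c2ccccc2OC)n1C`: 25000 nM

Two gaps place compound 3 at the low end of this small set, an end it shares with one other compound: a 1.3-fold lower number from compound 2 to compound 3 (0.12 log units; within the scatter), and a 2.8-fold lower number from compound 1 to compound 3 (0.45 log units; beyond the scatter).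

The next compound, compound 4 `COc1ccccc1-c1cnc(OCCCc2ccccc2)n1C`, keeps the shared core and alters only the side chain: benzyl in place of vinyl on a saturated chain carbon, two bonds along the chain from an oxygen on an aromatic ring. In words, this is benzyl in place of vinyl on a saturated chain carbon, two bonds along the chain from an oxygen on an aromatic ring.

The closest guide is the earlier growth of the same chain, which gave only a modest change: a 2.2-fold lower number from compound 1 to compound 2 (0.33 log units; beyond the scatter). Among the measured compounds shown here, none of the measured chains carries a ring, so the range must stay wide. A small move towards a lower number in this assay is expected, probably not beyond the scatter: the estimated step is a 1.6-fold lower number from compound 3 to compound 4 (0.19 log units; within the scatter).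

For compound 4 the expected value is 16000 nM, with an estimated range of 5000 nM to 50000 nM.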

Compound 4, half-maximal inhibitory concentration: 27000 nM
The estimate for compound 4 lay 1.7-fold (0.23 log units) below the measured number; low and high end bracket the measured number.
By their numbers in this assay, from the lowest: compounds 3, 4 and 2 (each within the scatter of the next); then compound 1.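

At this place on the side chain, a chain ending in a ring does about as well as the open chains in this assay: benzyl in place of vinyl, which brings in a six-membered aromatic ring, stays within the scatter (a 1.1-fold higher number from compound 3 to compound 4 (0.03 log units; within the scatter)), as does phenyl in place of propyl (a 1.2-fold lower number from compound 2 to compound 4 (0.09 log units; within the scatter)). Only compound 1 stands apart, with phenyl in place of methyl giving a modest step beyond the scatter (a 2.6-fold lower number from compound 1 to compound 4 (0.42 log units; beyond the scatter)), so a ring at the chain end keeps the gain already seen with compounds 2 and 3. No measurement here explains these results.

Still open, going by these compounds, is whether a chain ending in an amine or a carboxylic acid would shift the number further. A phenyl ring carrying a substituent such as a hydroxyl group also remains an open case.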